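A few compounds are considered here, and "the series" means these few. Any claim that something is new, unique, unknown or untested is made for them only; others in the source may bear on it.

The measured compounds:
Compound 1, `COc1cccc(-c2nn3cc(-c4cccc(N)c4)nc3s2)c1`, gives in a functional assay on L1210 cells (Mus musculus) for inhibition, read by cell counting, with a stated time of 2 days (on this read-out higher numbers stand for weaker inhibition and lower numbers for stronger inhibition), a value that is a limit of the assay, > 250000 nM.
Compound 2, `C=C(Br)C(=O)Nc1cccc(-c2cn3nc(Cc4ccc(OC)cc4)sc3n2)c1`, gives 1400 nM in this assay.
Compound 3, `COc1ccc(Cc2nn3cc(-c4cccc(N)c4)nc3s2)cc1`, gives 227000 nM in this assay.

Among the two compounds with a number in this assay, compound 2 stands lowest; its nearest neighbour is compound 3, reached by a 160-fold higher number from compound 2 to compound 3 (2.21 log units; beyond the scatter), where hydrogen replaces (1-bromoethenyl)carbonyl on a nitrogen on an aromatic ring. Among the compounds with values here, the single measured step therefore concerns that amide, which compound 2 and compound 4, `C=C(Br)C(=O)Nc1cccc(-c2cn3nc(-c4ccc(CC)cc4)sc3n2)c1`, share unchanged.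

The step from compound 2 to compound 4 is of another kind: 4-ethylphenyl in place of 4-methoxybenzyl on an aromatic carbon. Within the data shown here, no measured step bears directly on this exchange. Compound 1 carries a methoxyphenyl group bound directly to the core and compound 3 a 4-methoxybenzyl group, yet both values sit near the weak end and compound 1 is only a limit, so they do not set a direction.

The account therefore expects no step beyond the scatter, a 1.1-fold higher number from compound 2 to compound 4 (0.03 log units; within the scatter), and estimates compound 4 at 1500 nM, between 300 nM and 8000 nM.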

Compound 4, half-maximal inhibitory concentration: 2200 nM
Compound 4: the middle estimate sits 1.5-fold (0.17 log units) below what was measured; the measured number falls inside the stated range.
By their numbers in this assay, from the lowest: compounds 2 and 4 (each within the scatter of the next); then compound 3. At a limit, above all of these: compound 1.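

In this assay, the exchange of 4-methoxybenzyl for 4-ethylphenyl on an aromatic carbon of the five-membered aromatic ring gives a 1.6-fold higher number from compound 2 to compound 4 (0.20 log units; within the scatter), so these two groups cannot be told apart here while the (1-bromoethenyl)carbonyl amide stays in place. Within the data shown here, the earlier measured step concerned only that amide, so this is the first reading at this position, and it shows that compound 2 and compound 4 remain far from the weak end of the series even though the oxygen of the 4-methoxybenzyl group is gone and the aromatic ring of the new group is attached differently. Nothing measured here accounts for this result.

With only these two groups shown at this position, it remains open whether a longer chain in place of the ethyl group, or an amine or a carboxylic acid on that phenyl ring, would leave the number where it is. Going by these compounds, it also remains open how large the step for removing the amide would be with 4-ethylphenyl at this position, since that step is known only with 4-methoxybenzyl.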